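Trifluoromethyl on a pendant aromatic ring: compounds 1 through 4

The compounds below may be only part of what the source reports. "The series", "measured", "known", "first", "only" and "open" are said of these compounds alone.

Of the compounds shown here, three share a core and have been measured in an assay on CHO cells with metabotropic glutamate receptor 2 (Homo sapiens) as the target, read by FLIPR; a lower number here means a smaller maximal response, a higher number a larger maximal response. Compound 1 `Cn1c(CN2CCC(c3ccccc3)CC2)nc2ccccc21` gives 89%. Compound 2 `Cn1c(CN2CCN(c3ccc(C(F)(F)F)cn3)CC2)nc2ccccc21` gives 81%. Compound 3 `Cn1c(CN2CCN(c3ccccn3)CC2)nc2ccccc21` gives 100%. The values of compound 1 and compound 2 lie within the scatter of each other, while compound 3 stands beyond the scatter above compound 1; how the cores of compound 1 and compound 3 differ is not broken down here.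

One structural change is seen in a measured pair. From compound 3 to compound 2 the change is trifluoromethyl in place of hydrogen on an aromatic carbon, and it produced a number 19 percentage points lower from compound 3 to compound 2 (beyond the scatter) in this assay.

Compound 4 `Cn1c(CN2CCC(c3cccc(C(F)(F)F)c3)CC2)nc2ccccc21` is not yet measured. It arises from compound 1 by trifluoromethyl in place of hydrogen on an aromatic carbon. This is the same kind of change as from compound 3 to compound 2, but the surroundings differ: there the ring held one nitrogen and the new group sat two atoms from the ring nitrogen and para to a large group, whereas here the ring is of carbon only and the group sits meta to a large group.

From compound 1 to compound 4 a step of about a number 15 percentage points lower from compound 1 to compound 4 (beyond the scatter) is expected in this assay, resting on the lowering seen from compound 3 to compound 2. For compound 4 the estimate is 74%, from 60% to 88%.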

Compound 4, largest response reached (Emax), in percent of the reference or control that the assay uses: 94%
Compound 4: middle estimate off by 20 percentage points, on the low side, and the stated range ends below it.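

In this assay, trifluoromethyl in place of hydrogen on an aromatic carbon gave a number 5 percentage points higher from compound 1 to compound 4 (within the scatter), so on the core of compound 1 this change leaves no readable mark on the maximal response. Set beside the earlier case, the same change does not carry over as a fixed step from one core to another in this series, and its effect on one core could not be transferred to the other here:  the same change on two cores in this assay, a number 19 percentage points lower (beyond the scatter) from compound 3 to compound 2 and a number 5 percentage points higher (within the scatter) from compound 1 to compound 4, 24 percentage points apart, beyond the scatter of two such steps

These two pairs do not show what sets the gap, since the ring that carries the group, its place on that ring and the rest of the core all differ between them, and they offer no rule for a third core.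

The compounds shown leave open how a nitrile, a methoxy group or an amine in that same place on compound 1 would compare with trifluoromethyl. They also leave open whether trifluoromethyl at another place on the ring of compound 1 would give a similar result.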